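Changing One Group on a Compound at the Assay Limit

The source may report more compounds than this note shows. Statements on the series, on what has been measured and on what is new or still open speak of the compounds shown alone.

Compound 1 `COc1ccc(NC(=O)NCCNS(=O)(=O)c2ccc(-c3ccccc3OCc3ccccc3)s2)cc1` is the starting point here, tested in a functional assay on HL-60 cells (Homo sapiens) for inhibition, read by CCK-8 assay, with a stated time of 48 h; a higher number here means a weaker inhibitor, a lower number a stronger inhibitor. Compound 1 reads > 50000 nM, which is a limit of the assay and not a number. Two relatives give no number either. Compound 2 `COc1ccc(Oc2ccc([N+](=O)[O-])cc2-c2ccsc2S(=O)(=O)N2CCN(C(=S)Nc3ccc(Cl)cc3)CC2)cc1OC` reads > 50000 nM, again a limit. Compound 3 `O=C(NCCNS(=O)(=O)c1ccc(-c2ccccc2O[C@H]2CC[C@@H](O)CC2)s1)Nc1ccc([N+](=O)[O-])cc1` reads > 20000 nM, also a limit. Every reading so far is therefore a limit, so compound 1 has no exact place on the scale.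

The next structure is compound 4 `Cc1cc(C)cc(NC(=O)NCCNS(=O)(=O)c2ccc(-c3ccccc3OCc3ccccc3)s2)c1`. It carries 3,5-dimethylphenyl in place of 4-methoxyphenyl on an amide-type nitrogen. Among the measured compounds shown here, no two measured compounds differ in just one place, so there is no measured step to lean on. A small move toward stronger inhibition is expected, possibly none beyond the usual scatter, and the assay may again report only a limit. That expectation rests on compound 1, whose limit is > 50000 nM. The estimated change is an at least 1.6-fold lower number from compound 1 to compound 4 (0.22 log units; that floor lies within the scatter). For compound 4 the expected half-maximal inhibitory concentration is 30000 nM, with an estimated range from 8000 nM to 50000 nM.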

Compound 4, half-maximal inhibitory concentration: 2200 nM
The estimate for compound 4 lay 14-fold (1.13 log units) above the measured number; the measured number lies below the stated range.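

In this assay, putting 3,5-dimethylphenyl in place of 4-methoxyphenyl on the amide-type nitrogen gives an at least 22-fold lower number from compound 1 to compound 4 (1.35 log units; beyond the scatter), which shows that this single position can take a compound from the assay limit to a measurable inhibitor. Compound 1 reads > 50000 nM, a limit and not a number. As far as these compounds go, the true size of the step therefore stays unknown and only its floor can be stated, because the starting value sits at that limit: the limit of > 50000 nM in this assay, at which 2 of the 4 values shown sit.

Both groups hold 8 heavy atoms, but the swap removes the methoxy group and adds two methyl groups at once, and the compounds shown do not separate these two parts of the change. From the compounds shown here alone, it also remains open how a phenyl ring with no substituent, a cyclohexyl group or a ring bearing a carboxylic acid would behave at this nitrogen, and whether the same swap would give a similar gain on another version of the shared core.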